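Restoring an Alkoxy Group on the Pendant Ring

A few compounds are considered here, and "the series" means these few. Any claim that something is new, unique, unknown or untested is made for them only; others in the source may bear on it.

Compound 3 `COc1cc(-n2ncnc2-c2ccccc2)cc(OC)c1OC` carries no substituent on its pendant ring. In a functional assay on K562 cells (Homo sapiens) for antiproliferative activity, read by MTT assay, with a stated time of 72 h (on this read-out higher numbers stand for weaker inhibition and lower numbers for stronger inhibition), compound 3 gives > 10000 nM, which is a limit of the assay rather than a number. Compound 4 `CCOc1ccc(-c2ncnn2-c2cc(OC)c(OC)c(OC)c2)cc1` differs by ethoxy in place of hydrogen on an aromatic carbon. The relevant comparisons come from compound 1 `COc1cc(-n2ncnc2-c2ccc(OC(C)C)cc2)cc(OC)c1OC`, which has isopropoxy on that aromatic carbon. In this assay compound 1 gives 800 nM. Compound 2 `COc1cc(-n2ncnc2-c2ccc(F)cc2)cc(OC)c1OC` gives > 10000 nM, also a limit. Removing isopropoxy cost an at least 12-fold higher number from compound 1 to compound 3 (1.09 log units; beyond the scatter), and replacing it with fluoro cost an at least 12-fold higher number from compound 1 to compound 2 (1.09 log units; beyond the scatter); two of the three values sit at the limit of > 10000 nM in this assay, at which 2 of the 3 values shown sit. Given that compound 1 gives 800 nM with isopropoxy in that place, a large gain in potency is expected for compound 4, an at least 6.6-fold lower number from compound 3 to compound 4 (0.82 log units; beyond the scatter). Compound 4 is estimated at 1500 nM, between 500 nM and 6000 nM.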

Compound 4, half-maximal inhibitory concentration: 20 nM
Compound 4: middle estimate off by 75-fold (1.88 log units), on the high side, outside the stated range (below it).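

At this place on the pendant ring, ethoxy is worth far more than compound 1 alone could show: in this assay the change from hydrogen gives an at least 500-fold lower number from compound 3 to compound 4 (2.69 log units; beyond the scatter) and the change from fluoro gives an at least 500-fold lower number from compound 2 to compound 4 (2.69 log units; beyond the scatter). Compound 2 and compound 3 each stand at a limit of the assay, not a number: the limit of > 10000 nM in this assay, at which 2 of the 4 values shown sit. The two alkoxy groups are not interchangeable here, as removing one methyl from isopropoxy gives a 40-fold lower number from compound 1 to compound 4 (1.60 log units; beyond the scatter).

Going by these compounds, whether methoxy or a longer chain such as propoxy would do better at this place stays open. So does whether an amine there would keep any of the activity.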